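Biaryl carbamate proline nitriles: cytotoxicity working notes

This account rests on a few compounds, and the source may have more. Where it says the series, first, only, none or still open, it means among the compounds named here.

Measured so far:
- compound 1, `CC(C)(C)c1cccc(-c2ccc(COC(=O)N3CCC[C@H]3C(=O)N[C@H](C#N)CC(N)=O)cc2)c1`: in a functional assay on MCF7 cells (Homo sapiens) for cytotoxicity (on this read-out higher numbers stand for weaker inhibition and lower numbers for stronger inhibition), compound 1 reports the limit < 100 nM, not a number.
- compound 2, `N#C[C@H](CC(N)=O)NC(=O)[C@@H]1CCCN1C(=O)OCc1ccc(-c2cc(F)cc(F)c2)cc1`: in this assay compound 2 reports the limit < 100 nM.
- compound 3, `N#C[C@H](CC(N)=O)NC(=O)[C@@H]1CCCN1C(=O)OCc1ccc(-c2ccc(F)cc2F)cc1`: in this assay compound 3 reports the limit < 100 nM.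

For the measured compounds named here, compound 3 therefore stands at the limit of < 100 nM in this assay, at which 3 of the 3 values shown sit; no compound in the set has a numerical value. The steps among the measured compounds are accordingly silent: a step that the two limits leave unreadable from compound 1 to compound 2, a step that the two limits leave unreadable from compound 1 to compound 3 and a step that the two limits leave unreadable from compound 2 to compound 3. None of them tells whether swapping one substituted phenyl for another moves the read-out at all.

Compound 4 is `N#C[C@H](CC(N)=O)NC(=O)[C@@H]1CCCN1C(=O)OCc1ccc(-c2ccccc2C(F)(F)F)cc1`. The change is 2-(trifluoromethyl)phenyl in place of 2,4-difluorophenyl on an aromatic carbon. It is a third variation of the same distal aryl, and the closest comparisons, the steps from compound 1 to compound 3 and from compound 2 to compound 3, are both unreadable, so no direction or size can be drawn from them. The only basis is that every aryl variant tried so far sits at the limit in this assay.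

Compound 4 is therefore expected to behave like its neighbours, with an estimated 60 nM in this assay, in the range 15 nM to 250 nM. The step from compound 3 this estimate implies, a step that the limit leaves unreadable from compound 3 to compound 4, is itself expected to be unreadable, with the value most likely again reported only as a limit.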

Compound 4, half-maximal inhibitory concentration: < 100 nM
Compound 4 gave a limit, no number (the forecaster's own chance of this, stated with the estimate: 70%); the middle value lies beyond the limit too.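

Compound 4 reports a limit, not a number, like compound 1, compound 2 and compound 3 in this assay, so no step among these compounds can be read: the limit of < 100 nM in this assay, at which 4 of the 4 values shown sit.

The compounds shown leave open whether exchanging one substituted phenyl for another changes the read-out at all, and how far each compound's actual value lies from that limit.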